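From 1-benzothiophen-5-yl to 1H-indazol-5-yl: clearance in question

The source may hold more compounds than are shown below. What is called first, only, known or untested is meant among the compounds shown, and "the series" means these compounds.

Of the compounds shown here, three that share one core have been measured so far in an ADME assay (liver) for metabolic stability, with Liver microsome (Homo sapiens) as the target, using microsomes and NADPH, with a stated time of 30 min, tested at 1 uM (a higher number here means faster removal of the compound, a lower number slower removal), for this series. Compound 1 (`Nc1ccc(S(=O)(=O)N2CCN(c3ncc(C(O)(C(F)(F)F)C(F)(F)F)cc3C#CCCO)CC2)cn1`) gives < 14 mL.min-1.g-1 and this is a limit of the assay, not a number. Compound 2 (`Nc1ccc(S(=O)(=O)N2CCN(c3ncc(C(O)(C(F)(F)F)C(F)(F)F)cc3-c3ccoc3)CC2)cn1`) gives < 14 mL.min-1.g-1 and that too is a limit. Among the compounds with values here, compound 3 (`Nc1ccc(S(=O)(=O)N2CCN(c3ncc(C(O)(C(F)(F)F)C(F)(F)F)cc3-c3ccc4sccc4c3)CC2)cn1`) gives 48 mL.min-1.g-1 and so holds the only actual number in the set. The measured steps leading to it are an at least 3.4-fold higher number from compound 1 to compound 3 (0.53 log units; beyond the scatter) and an at least 3.4-fold higher number from compound 2 to compound 3 (0.53 log units; beyond the scatter) and in each of them 1-benzothiophen-5-yl is the group that enters.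

Compound 4 (`Nc1ccc(S(=O)(=O)N2CCN(c3ncc(C(O)(C(F)(F)F)C(F)(F)F)cc3-c3ccc4[nH]ncc4c3)CC2)cn1`) differs from compound 3 by a single change: 1H-indazol-5-yl in place of 1-benzothiophen-5-yl on an aromatic carbon in words, 1H-indazol-5-yl in place of 1-benzothiophen-5-yl on an aromatic carbon. Within the data shown here, both groups hold a five-membered aromatic ring and a six-membered aromatic ring of carbon only, and no measured step tests this exchange directly. The expectation therefore leans on an at least 3.4-fold higher number from compound 2 to compound 3 (0.53 log units; beyond the scatter) as a guide: that rise arrived with 1-benzothiophen-5-yl, which now leaves, so part of it may be lost again. The expected change in this assay is a 2.4-fold lower number from compound 3 to compound 4 (0.38 log units; beyond the scatter) as a modest fall, and the estimate is a loose one. Compound 4 is estimated at 20 mL.min-1.g-1 with an expected range from 9 mL.min-1.g-1 to 45 mL.min-1.g-1 as its span.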

Compound 4, intrinsic clearance in microsomes: 27 mL.min-1.g-1
Compound 4: middle estimate off by 1.4-fold (0.13 log units), on the low side, and the stated range covers the measured number.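

At this place on the shared core, the exchange gives a 1.8-fold lower number from compound 3 to compound 4 (0.25 log units; within the scatter) in this assay so the two groups cannot be told apart here, even though 1H-indazol-5-yl carries two ring nitrogens and a hydrogen-bond donor where 1-benzothiophen-5-yl carries a sulfur and no donor. Compound 3 stood clearly apart from compounds 1 and 2, whereas the readings an at least 1.9-fold higher number from compound 2 to compound 4 (0.28 log units; that floor lies within the scatter) and an at least 1.9-fold higher number from compound 1 to compound 4 (0.28 log units; that floor lies within the scatter) do not set compound 4 clearly apart from them. These two steps are only floors, and their true size cannot be read: the limit of < 14 mL.min-1.g-1 in this assay, at which 2 of the 4 values shown sit.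

Both the sulfur and the ring hydrogen on nitrogen changed in this one exchange, so a closer pair such as 1H-indol-5-yl or 1-benzofuran-5-yl would be needed to separate what each contributes to the clearance at this place. The compounds shown also leave open how a plain phenyl ring, a pyridine, a carboxylic acid or an amine on a short chain would behave at the same place, and whether any of them would stay at the limit of the assay.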